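Ester to alkyne swap on a diaryl pentenyl chain

The compounds below may be only part of what the source reports. "The series", "measured", "known", "first", "only" and "open" are said of these compounds alone.

Measured compounds:
- compound 1 `COC(=O)CCCC=C(c1cc(Br)c(OC)c(C(=O)OC)c1)c1cc(Br)c(OC)c(C(=O)OC)c1` — 0.103 h
- compound 2 `COC(=O)CCCC=C(c1cc(Cl)c(OC)c(C(=O)OC)c1)c1cc(Cl)c(OC)c(C(=O)OC)c1` — 0.0967 h
- compound 3 `C#CCCCC=C(c1cc(Br)c(OC)c(C(=O)OC)c1)c1cc(Br)c(OC)c(C(=O)OC)c1` — 0.315 h

All three numbers come from an ADME assay on the whole organism (plasma) for metabolic stability, with Rattus norvegicus as the target; on this read-out lower numbers stand for a shorter-lived compound and higher numbers for a longer-lived compound. Compound 1 and compound 2 differ in more than one place; the difference between the two cores is not broken down here. Their two values in this assay lie within the scatter of each other.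

One change is seen once so far: ethynyl in place of methoxycarbonyl on a saturated chain carbon, three bonds along the chain from a double-bonded chain carbon. It gave a 3.1-fold higher number from compound 1 to compound 3 (0.49 log units; beyond the scatter). Compound 4 `C#CCCCC=C(c1cc(Cl)c(OC)c(C(=O)OC)c1)c1cc(Cl)c(OC)c(C(=O)OC)c1`, not yet measured, carries the same change on the core of compound 2: ethynyl in place of methoxycarbonyl on a saturated chain carbon, three bonds along the chain from a double-bonded chain carbon. The two place descriptions are the same, so this is the same change on a different core.

The expectation for compound 4 rests on a single pair. For the measured compounds named here, because a 3.1-fold higher number from compound 1 to compound 3 (0.49 log units; beyond the scatter) is the only prior step of this kind, and because compound 2 gives 0.0967 h, the step is expected to be a 3.1-fold higher number from compound 2 to compound 4 (0.49 log units; beyond the scatter), close to the earlier one. Compound 4 is therefore estimated at 0.3 h, with a likely range from 0.15 h to 0.6 h. Whether the step transfers unchanged to the second core remains to be seen.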

Compound 4, half-life: 0.343 h
Estimate against measurement, compound 4: 1.1-fold (0.06 log units) below; the range from low to high includes it.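

In this assay, ethynyl in place of methoxycarbonyl on a saturated chain carbon, three bonds along the chain from a double-bonded chain carbon, gives a 3.5-fold higher number from compound 2 to compound 4 (0.55 log units; beyond the scatter), and the two steps seen so far match: the same change on two cores in this assay, a 3.1-fold higher number (0.49 log units; beyond the scatter) from compound 1 to compound 3 and a 3.5-fold higher number (0.55 log units; beyond the scatter) from compound 2 to compound 4, 1.2-fold (0.06 log units) apart, within the scatter of two such steps

Across these two cores, then, the change carries over with its size intact, and the step from one core gives a usable guide to the other. This rests on two pairs only; it does not show that the step would hold on any further core, and it says nothing about why the half-life rises.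

The compounds shown leave open whether another group at the same place on the chain, such as a nitrile, an amide or a carboxylic acid, would give a similar step, and whether a shorter or longer chain would change it. As far as these compounds go, all four compounds also keep the methoxycarbonyl groups on the core, so the effect of replacing those with a carboxylic acid or an amide in this assay remains open.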